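The source may hold more compounds than are shown below. What is called first, only, known or untested is meant among the compounds shown, and "the series" means these compounds.

Going by the values given here, in a functional assay on HepG2 cells (Homo sapiens) for cytotoxicity, read by sulforhodamine B assay, with a stated time of 24 h (a lower number here means a stronger inhibitor, a higher number a weaker inhibitor), compound 1 `Cc1ccc(/N=C2\C(=O)Nc3ccc(S(=O)(=O)N4CCOCC4)cc32)cc1` gives 12800 nM and compound 2 `O=C1Nc2ccc(S(=O)(=O)N3CCOCC3)cc2/C1=N/NC(=O)c1ccccc1` gives 18100 nM, so compound 2 stands level with the only other measured compound, within the usual scatter. Still unmeasured, compound 3 `O=C1Nc2ccc(S(=O)(=O)N3CCOCC3)cc2/C1=N/c1ccc(C(=O)O)cc1` has 4-carboxyphenyl in place of benzamido on a double-bonded nitrogen. Among the compounds with values here, the one measured step at this place is a 1.4-fold higher number from compound 1 to compound 2 (0.15 log units; within the scatter), a small one, so no step beyond the scatter is expected in this assay. The estimate for compound 3 is 20000 nM, with an expected range of 8000 nM to 50000 nM. That expected change is a 1.1-fold higher number from compound 2 to compound 3 (0.04 log units; within the scatter).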

Compound 3, half-maximal inhibitory concentration: 23100 nM
For compound 3 the middle estimate is 1.2-fold (0.06 log units) below the measured one; measured number inside the range.
By their numbers in this assay, from the lowest: compounds 1, 2 and 3 (each within the scatter of the next).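

In this assay, carboxy in place of methyl on an aromatic carbon gives a 1.8-fold higher number from compound 1 to compound 3 (0.26 log units; within the scatter), and 4-carboxyphenyl in place of benzamido gives a 1.3-fold higher number from compound 2 to compound 3 (0.11 log units; within the scatter). Both steps lie within the scatter, so this position has now taken three different groups on the double-bonded nitrogen with no step beyond the scatter. No measurement shown here accounts for this result. On these data alone, an amine or a longer chain on the aromatic ring at this place remains open, as does whether either would produce a step beyond the scatter.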